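The source may report more compounds than this note shows. Statements on the series, on what has been measured and on what is new or still open speak of the compounds shown alone.

Measured in an assay on isolated protein for inhibition of ubiquitin carboxyl-terminal hydrolase 7 (Homo sapiens), with stated times of 30 min and 2 h (a higher number here means a weaker inhibitor, a lower number a stronger inhibitor), so far: compound 1 `Cn1nc2c(=O)n(CC3(O)CCN(Cc4ccc(-c5n[nH]c(=O)o5)cc4Cl)CC3)cnc2c1-c1ccc(CN)cc1` gives 171 nM; compound 3 `Cn1nc2c(=O)n(CC3(O)CCN(Cc4ccc(-c5ccc[nH]5)cc4Cl)CC3)cnc2c1-c1ccc(CN)cc1` gives 193 nM; compound 2 `CC(C)NCc1ccc(-c2c3ncn(CC4(O)CCN(Cc5ccc(-c6ccco6)cc5Cl)CC4)c(=O)c3nn2C)cc1` gives 29.1 nM.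

Compound 3 holds the highest of the three numbers. Its nearest neighbour is compound 1, the step being a 1.1-fold higher number from compound 1 to compound 3 (0.05 log units; within the scatter). Compound 2 sits much lower, but it differs from compound 3 in more than one place, so that pair is left as it stands.

Compound 4 `Cn1nc2c(=O)n(CC3(O)CCN(Cc4ccc(-c5cccs5)cc4Cl)CC3)cnc2c1-c1ccc(CN)cc1`: thiophen-2-yl in place of 1H-pyrrol-2-yl on an aromatic carbon. Within the data shown here, the one measured step at this position, a 1.1-fold higher number from compound 1 to compound 3 (0.05 log units; within the scatter), exchanged one five-membered aromatic ring for another and stayed inside the scatter. The same is expected here: no step beyond the scatter in this assay, so that a 1.0-fold lower number from compound 3 to compound 4 (0.01 log units; within the scatter) is the estimated move. Compound 4 is expected at 190 nM, in the range 90 nM to 400 nM.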

Compound 4, half-maximal inhibitory concentration: 38.6 nM
Beside the measured number, compound 4's estimate is 4.9-fold (0.69 log units) above it; measured number below the stated range.
By their numbers in this assay, from the lowest: compounds 2 and 4 (each within the scatter of the next); then compounds 1 and 3 (each within the scatter of the next).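

In this assay, the ring on this aromatic carbon matters more than the step between compound 1 and compound 3 suggested. Thiophen-2-yl in place of 1H-pyrrol-2-yl gives a 5.0-fold lower number from compound 3 to compound 4 (0.70 log units; beyond the scatter), with sulfur replacing nitrogen in a ring of equal heavy-atom count. Against the ring of compound 1 the picture is similar, a 4.4-fold lower number from compound 1 to compound 4 (0.65 log units; beyond the scatter), so five-membered aromatic rings are not interchangeable at this position. From the compounds shown here alone, whether thiophen-3-yl or a phenyl ring on the same carbon would hold the number of compound 4 remains open. No available evidence bears on what lies behind this step.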